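Chloro for Fluoro on a Fluorinated Analogue

The source may report more compounds than this note shows. Statements on the series, on what has been measured and on what is new or still open speak of the compounds shown alone.

Four compounds share one core. Compound 1 has the structure `O=C(Nc1ccc(Oc2ccnc3[nH]ccc23)cc1)c1cn(-c2ccc(F)cc2)c2ccccc2c1=O`, compound 2 is `O=C(Nc1ccc(Oc2ccnc3[nH]ccc23)cc1)c1cn(-c2ccc(Cl)cc2)c2ccccc2c1=O`, compound 3 is `O=C(Nc1ccc(Oc2ccnc3[nH]ccc23)c(F)c1)c1cn(-c2ccc(F)cc2)c2ccccc2c1=O`, and compound 4, not yet measured, is `O=C(Nc1ccc(Oc2ccnc3[nH]ccc23)c(F)c1)c1cn(-c2ccc(Cl)cc2)c2ccccc2c1=O`. In a functional assay on HepG2 cells (Homo sapiens) for inhibition, read by MTT assay, with a stated time of 72 h (a lower number here means a stronger inhibitor, a higher number a weaker inhibitor), compound 1 gives 450 nM. In this assay compound 2 gives 250 nM, and compound 3 gives 270 nM. Compound 2 differs from compound 1 by chloro in place of fluoro on an aromatic carbon, and this gave a 1.8-fold lower number from compound 1 to compound 2 (0.26 log units; within the scatter). Compound 3 differs from compound 1 by fluoro in place of hydrogen on an aromatic carbon, which gave a 1.7-fold lower number from compound 1 to compound 3 (0.22 log units; within the scatter). Compound 4 differs from compound 3 by chloro in place of fluoro on an aromatic carbon, the same change that turned compound 1 into compound 2, made at the same place. Across these three compounds no two values lie apart by more than the scatter, so none can be called stronger or weaker than another. In this assay the step to compound 4 is expected to be a 1.8-fold lower number from compound 3 to compound 4 (0.26 log units; within the scatter), because the same change earlier gave a 1.8-fold lower number from compound 1 to compound 2 (0.26 log units; within the scatter). Compound 4 is therefore estimated at 150 nM, with a likely range from 80 nM to 300 nM.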

Compound 4, half-maximal inhibitory concentration: 380 nM
For compound 4 the middle estimate is 2.5-fold (0.40 log units) below the measured one; the whole stated range lies below it.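

In this assay, the exchange of 4-fluorophenyl for 4-chlorophenyl on the fluorinated core gave a 1.4-fold higher number from compound 3 to compound 4 (0.15 log units; within the scatter), and this step does not differ from its earlier counterpart by more than the scatter allows: the same change on two cores in this assay, a 1.8-fold lower number (0.26 log units; within the scatter) from compound 1 to compound 2 and a 1.4-fold higher number (0.15 log units; within the scatter) from compound 3 to compound 4, 2.5-fold (0.40 log units) apart, within the scatter of two such steps. The addition of fluoro in place of hydrogen, read on the chloro compounds, gave a 1.5-fold higher number from compound 2 to compound 4 (0.18 log units; within the scatter), and it likewise agrees with its earlier counterpart within the scatter: the same change on two cores in this assay, a 1.7-fold lower number (0.22 log units; within the scatter) from compound 1 to compound 3 and a 1.5-fold higher number (0.18 log units; within the scatter) from compound 2 to compound 4, 2.5-fold (0.40 log units) apart, within the scatter of two such steps. The four compounds therefore give no sign that either change behaves differently on the two cores, but with every step within the scatter they do not show that either change has a real effect, that such an effect carries from one core to the other, or that the opposite signs of the paired steps mean anything.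

The compounds shown hold only fluoro and chloro on the aromatic carbon para to a large group. On these data alone, whether a methoxy group, a nitrile or an amine at that place would give a step beyond the scatter, and whether such a step would carry between the two cores, remains open.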